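Acid dissociation across variants at the far end of the shared core

The source may hold more compounds than are shown below. What is called first, only, known or untested is meant among the compounds shown, and "the series" means these compounds.

Measured so far in a physicochemical assay for acid dissociation:
compound 1 `COc1cccc(CNCCCNc2ccnc3cc(Oc4ccc(Cl)cc4)ccc23)c1O` gives 9.28
compound 2 `COc1cccc(CNCCCNc2ccnc3cc(CCC(C)C)ccc23)c1O` gives 9.47
compound 3 `COc1cccc(CNCCCNc2ccnc3cc(Cc4ccc(F)cc4)ccc23)c1O` gives 9.47

Compound 3 stands level with compound 2 at the digits printed; the two share the highest reading of the three. The step from compound 2 to compound 3 is no change at the digits printed from compound 2 to compound 3 (within the scatter), and from compound 1 to compound 3 it is a number 0.19 log units higher from compound 1 to compound 3 (within the scatter). Compound 1 is the furthest of the three from compound 3, and even that gap stays within the scatter.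

Compound 4 `COc1cccc(CNCCCNc2ccnc3cc(Cc4ccc(F)cc4Cl)ccc23)c1O` differs from compound 3 by chloro in place of hydrogen on an aromatic carbon. The change sits on the 4-fluorophenyl group, at the same far end of the shared core where all three measured compounds differ from one another.

For the measured compounds named here, three measured steps bear on this: a number 0.19 log units higher from compound 1 to compound 2 (within the scatter), a number 0.19 log units higher from compound 1 to compound 3 (within the scatter) and no change at the digits printed from compound 2 to compound 3 (within the scatter). Each swaps the whole group at that end of the core, and none moves this assay beyond the scatter. A single chloro added within that group is a smaller alteration than any of them. The expectation for the step from compound 3 to compound 4 is therefore no change beyond the scatter, a number 0.02 log units lower from compound 3 to compound 4 (within the scatter).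

Compound 4 is estimated at 9.45, expected within 9.15 to 9.75.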

Compound 4, acid dissociation constant: 9.47
For compound 4 the middle estimate is 0.02 log units below the measured one, and the stated range covers the measured number.
By their numbers in this assay, from the lowest: compounds 1, 2, 3 and 4 (each within the scatter of the next).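

In this assay, for the compounds shown here, the chloro on compound 4 is the first change in this set made inside a group at this position rather than a swap of the whole group, and it reads as no change at the digits printed from compound 3 to compound 4 (within the scatter) for the 4-fluorobenzyl to 2-chloro-4-fluorobenzyl change. The whole-group comparisons that take in the new compound agree, with no change at the digits printed from compound 2 to compound 4 (within the scatter) against the isopentyl variant and a number 0.19 log units higher from compound 1 to compound 4 (within the scatter) against the 4-chlorophenoxy variant, so all four compounds at this end of the shared core now lie within the scatter of one another. No measurement at hand accounts for this flat reading at the position.

Going by these compounds, whether this flat reading would hold with a primary amine or a carboxylic acid on the benzyl group, or with a longer chain in place of isopentyl, stays open. Also open, on these data alone, is which site in the shared core gives up the proton in this assay and whether a change elsewhere on the core would move the reading beyond the scatter.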